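This account rests on a few compounds, and the source may have more. Where it says the series, first, only, none or still open, it means among the compounds named here.

Series notes. Compound 1 `CCN(CC)CCCOc1cc(OC)ccc1-c1cc(-c2ccccc2)no1` gives 14.3% in a functional assay on the whole organism (blood, strain Charles Foster/Wistar albino) with Rattus norvegicus as the target, with a stated time of 30 min, at a dose of 100 mg/kg by the oral route; on this read-out lower numbers stand for less inhibition and higher numbers for more inhibition at the one dose given (going by the name of the read-out). Compound 2 `CCCCN(C)CCCOc1cc(OC)ccc1-c1cc(-c2ccccc2)no1` gives 15% in this assay, and the step of a number 0.7 percentage points higher from compound 1 to compound 2 (within the scatter) lies within the scatter. Compound 3 `CCOC(=O)COc1cc(OC)ccc1-c1cc(-c2ccccc2)no1` gives 10.4% in this assay; its number is the lowest of the three, yet the steps of a number 3.9 percentage points lower from compound 1 to compound 3 (within the scatter) and a number 4.6 percentage points lower from compound 2 to compound 3 (within the scatter) both fall within the scatter, so no order among the three can be read from these numbers. Compound 4 `CCOC(=O)CCCOc1cc(OC)ccc1-c1cc(-c2ccccc2)no1` remains to be measured. 2-(ethoxycarbonyl)ethyl in place of ethoxycarbonyl on a saturated chain carbon bound to an oxygen on an aromatic ring The change keeps the ethoxycarbonyl and extends the side chain at the same place. Among the compounds with values here, the steps that bear on it are a number 3.9 percentage points lower from compound 1 to compound 3 (within the scatter) and a number 4.6 percentage points lower from compound 2 to compound 3 (within the scatter), where exchange of 2-(diethylamino)ethyl or 2-(butyl(methyl)amino)ethyl for ethoxycarbonyl at this place moved the number by less than the scatter. A smaller extension within the same ester chain is therefore expected to give no step beyond the scatter, a number 1.6 percentage points higher from compound 3 to compound 4 (within the scatter). Compound 4 is estimated at 12%, with an expected range from 4% to 21%.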

Compound 4, a percentage reported as inhibition, in the whole organism at one dose (the size of the read-out at that dose, not a potency): 4.6%
For compound 4 the middle estimate is 7.4 percentage points above the measured one; measured number inside the range.
By their numbers in this assay, from the lowest: compounds 4, 3, 1 and 2 (each within the scatter of the next, the first and the last beyond it).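

In this assay, extending the side chain to 2-(ethoxycarbonyl)ethyl on the saturated chain carbon bound to an oxygen on an aromatic ring gives a number 5.8 percentage points lower from compound 3 to compound 4 (within the scatter), so these numbers do not separate the two ester chain lengths. Within the data shown here, at the same chain length, ethoxycarbonyl in place of butyl(methyl)amino gives a number 10.4 percentage points lower from compound 2 to compound 4 (beyond the scatter), the first step beyond the scatter, whereas ethoxycarbonyl in place of diethylamino gives a number 9.7 percentage points lower from compound 1 to compound 4 (within the scatter), so the separation between ester and amine holds for only one of the two amines. No measured information bears on what lies behind these steps.

Still open, from the compounds shown here alone, is how a carboxylic acid in place of the ethyl ester on this chain would read. Also open, going by these compounds, are a longer chain than 3-(ethoxycarbonyl)propyl and a cyclic amine such as morpholine at the chain end.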